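Swapping chloro for methoxy on compound 1

This account rests on a few compounds, and the source may have more. Where it says the series, first, only, none or still open, it means among the compounds named here.

In a functional assay on KM12 cells (Homo sapiens) for inhibition (on this read-out higher numbers stand for weaker inhibition of growth and lower numbers for stronger inhibition of growth), compound 1 (`COc1cc(/C=C/C(=O)c2cccc(-n3cc(-c4ccc(Cl)cc4)[nH]c3=O)c2)cc(OC)c1OC`) gives 5450 nM as the highest number of the three measured, while compound 2 (`COc1cc(/C=C/C(=O)c2cccc(-n3cc(-c4ccccc4)[nH]c3=O)c2)ccc1O`) gives 1610 nM and compound 3 (`COc1ccc(-c2cn(-c3cccc(C(=O)/C=C/c4ccc(O)c(OC)c4)c3)c(=O)[nH]2)cc1`) gives 1770 nM for clearly stronger inhibition. Compound 4 (`COc1ccc(-c2cn(-c3cccc(C(=O)/C=C/c4cc(OC)c(OC)c(OC)c4)c3)c(=O)[nH]2)cc1`) differs from compound 1 by one change (methoxy in place of chloro on an aromatic carbon), methoxy in place of chloro on an aromatic carbon. Among the measured compounds shown here, no measured step makes this exact swap. The closest one, methoxy in place of hydrogen on an aromatic carbon, is a 1.1-fold higher number from compound 2 to compound 3 (0.04 log units; within the scatter) and stays within the scatter. So in this assay only a small change is expected: the estimated 1.6-fold lower number from compound 1 to compound 4 (0.19 log units; within the scatter) does not go beyond the scatter. For compound 4 the estimate is 3500 nM with an expected range from 1500 nM to 7500 nM on this read-out.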

Compound 4, concentration for 50% growth inhibition: 1420 nM
For compound 4 the middle estimate is 2.5-fold (0.39 log units) above the measured one; measured number below the stated range.
By their numbers in this assay, from the lowest: compounds 4, 2 and 3 (each within the scatter of the next); then compound 1.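

In this assay, 4-methoxyphenyl in place of 4-chlorophenyl gives a 3.8-fold lower number from compound 1 to compound 4 (0.58 log units; beyond the scatter) and goes beyond the scatter, so this position, para to a large group, can shift the number, which the hydrogen-to-methoxy step a 1.1-fold higher number from compound 2 to compound 3 (0.04 log units; within the scatter) did not show. With that methoxy kept, 3,4,5-trimethoxyphenyl in place of 4-hydroxy-3-methoxyphenyl gives a 1.2-fold lower number from compound 3 to compound 4 (0.10 log units; within the scatter) and stays within the scatter. No supporting measurement explains the difference between chloro and methoxy here.

The compounds shown leave open how an amine or a carboxylic acid at this position would read, and whether the chloro-to-methoxy step holds with 4-hydroxy-3-methoxyphenyl in place.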